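A Chlorophenyl Variant of Three Growth-Inactive Sulfonamides

The compounds below may be only part of what the source reports. "The series", "measured", "known", "first", "only" and "open" are said of these compounds alone.

Compound 1, `COc1cccc(S(=O)(=O)NC2=NCCN2C(=S)SN2CCn3c2nsc3=S)c1`, is one of three close relatives tested in a functional assay on KYSE-510 cells (Homo sapiens) for antiproliferative activity, read by crystal violet staining, with a stated time of 96 h; a lower number here means a stronger inhibitor of growth, a higher number a weaker inhibitor of growth. In this assay compound 1 gives >= 20000 nM, which is a limit of the assay rather than a measured number. Compound 2, `O=S(=O)(NC1=NCCN1C(=S)SN1CCn2c1nsc2=S)c1ccc(OC(F)(F)F)cc1`, gives >= 20000 nM, also a limit. Compound 3, `CC(=O)Nc1ccc(S(=O)(=O)NC2=NCCN2C(=S)SN2CCn3c2nsc3=S)cc1`, gives >= 20000 nM, again a limit. All three sit at the limit of >= 20000 nM in this assay, at which 3 of the 3 values shown sit, so the step that the two limits leave unreadable from compound 1 to compound 3 and the step that the two limits leave unreadable from compound 2 to compound 3 cannot be read in size or direction. Compound 4, `O=S(=O)(NC1=NCCN1C(=S)SN1CCn2c1nsc2=S)c1ccc(Cl)cc1`, has not yet been measured. It differs from compound 1 by 4-chlorophenyl in place of 3-methoxyphenyl on a sulfonyl sulfur. Neither measured step bears on this change in a readable way, since each begins and ends at the limit. With every relative at the limit, compound 4 is expected to stay there as well, so the step of a number no higher from compound 1 to compound 4 (the limit leaves the size open) is expected to be small or absent. Compound 4 is therefore estimated at 20000 nM, within a range from 6000 nM to 60000 nM.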

Compound 4, concentration for 50% growth inhibition: >= 20000 nM
Compound 4: only a limit was reported; the forecaster's own chance of this, stated with the estimate: 75%; the middle value sits exactly at the limit.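

In this assay compound 4 gives >= 20000 nM which is a limit and not a number. Its steps to compound 1, compound 2 and compound 3 therefore cannot be read in size or direction: the limit of >= 20000 nM in this assay, at which 4 of the 4 values shown sit. From the compounds shown here alone, how strongly each of these four compounds inhibits growth, and whether their aromatic groups differ in effect, remains open.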